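A few compounds are considered here, and "the series" means these few. Any claim that something is new, unique, unknown or untested is made for them only; others in the source may bear on it.

Measured compounds:
- compound 1, `Cn1c(=O)c(CCO)c(-c2ccccc2Cl)c2cc(Cl)ccc21`, 34000 nM in an ADME assay on HepG2 2.2.15 cells (Homo sapiens) for cytotoxicity; on this read-out lower numbers stand for higher toxicity in this test and higher numbers for lower toxicity in this test
- compound 2, `O=CCc1c(-c2ccccc2Cl)c2cc(Cl)ccc2[nH]c1=O`, 120000 nM in this assay

Compound 2 gives the highest of the two numbers in this assay; compound 1 sits lower, and the gap between compound 1 and compound 2 is beyond the scatter. Within the data shown here, no step between measured compounds that differ in one place is available, so no reference step for this kind of change exists.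

Compound 3, `CC(=O)OCC(=O)OCCc1c(-c2ccccc2Cl)c2cc(Cl)ccc2[nH]c1=O`, is not yet measured. It differs from compound 2 in one place: (((acetoxymethyl)carbonyl)oxy)methyl in place of formyl on a saturated chain carbon bound to an aromatic carbon.

Nothing in the two measured compounds tells how such a change moves the number in this assay. A modest step downward is expected from compound 2 to compound 3, about a 1.7-fold lower number from compound 2 to compound 3 (0.23 log units; within the scatter), but within the scatter cannot be excluded. Compound 3 is estimated at 70000 nM, with a range from 25000 nM to 200000 nM.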

Compound 3, half-maximal cytotoxic concentration: 100000 nM
For compound 3 the middle estimate is 1.4-fold (0.15 log units) below the measured one; measured number inside the range.
By their numbers in this assay, from the lowest: compound 1; then compounds 3 and 2 (each within the scatter of the next).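

In this assay, among these compounds, (((acetoxymethyl)carbonyl)oxy)methyl in place of formyl on a saturated chain carbon bound to an aromatic carbon gives a 1.2-fold lower number from compound 2 to compound 3 (0.08 log units; within the scatter) and is the first step that can be read at this position. The entering group has more heavy atoms and more hydrogen-bond acceptors than formyl, yet the read-out shows no change beyond the scatter, so this position accepts at least this one much larger group in this test. The data on hand offer no explanation for this outcome.

Steps involving compound 1 cannot be read, as it differs from the others in more than one place. As far as these compounds go, whether a chain ending in a carboxylic acid or an amine, or a longer alkyl chain, would also stay within the scatter of compound 2 remains open.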